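Hydroxy for chloro on the diarylmethyl ring

The source may report more compounds than this note shows. Statements on the series, on what has been measured and on what is new or still open speak of the compounds shown alone.

Two acids sharing one core have been measured. Compound 1 `O=C(O)Cc1sc(C(c2ccccc2)c2ccc(Cl)cc2)nc1-c1ccc(Cl)cc1` gives 45 nM in an in vitro assay on HEK385-7 cells for displacement of a labelled ligand from prostaglandin D2 receptor 2 (Homo sapiens); a higher number here means a weaker inhibitor, a lower number a stronger inhibitor. Compound 2 `O=C(O)Cc1sc(C(c2ccccc2)c2ccc(Cl)cc2)nc1-c1ccc(F)cc1` gives 14 nM in this assay. Among the measured compounds shown here, the single step between them, a 3.2-fold lower number from compound 1 to compound 2 (0.51 log units; beyond the scatter), concerns a halogen on the ring bonded directly to the core. Compound 2 therefore stands with the lowest of the two numbers; its nearest neighbour is compound 1, whose number is higher by a margin beyond the scatter.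

Compound 3 `O=C(O)Cc1sc(C(c2ccccc2)c2ccc(O)cc2)nc1-c1ccc(F)cc1` is not yet measured. It differs from compound 2 by hydroxy in place of chloro on an aromatic carbon. For the measured compounds named here, no measured step touches that ring; the step from compound 1 to compound 2 swaps one halogen for another elsewhere, so it bears only loosely on the present change. With no direct guide, a modest shift in either direction in this assay cannot be excluded. Compound 3 is estimated at 40 nM, within 10 nM to 160 nM, which means an expected step of a 2.9-fold higher number from compound 2 to compound 3 (0.46 log units; beyond the scatter).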

Compound 3, half-maximal inhibitory concentration: 3.4 nM
Estimate against measurement, compound 3: 12-fold (1.07 log units) above, and the stated range ends above it.
By their numbers in this assay, from the lowest: compound 3; then compound 2; then compound 1.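

The ring position carrying chloro in compound 2 responds to substitution and tolerates a change of group type: 4-hydroxyphenyl in place of 4-chlorophenyl gives a lower number in this assay (a 4.1-fold lower number from compound 2 to compound 3 (0.61 log units; beyond the scatter)). The incoming hydroxy counts one hydrogen-bond donor and one hydrogen-bond acceptor, whereas the departing chloro counts neither, so a halogen is not needed here for a low number. Nothing measured explains the drop, and no supporting data bear on its origin.

The compounds shown cannot separate a role for the hydroxy hydrogen from other differences between the two groups; a methoxy or an amine at this position would test that. From the compounds shown here alone, it also remains open whether hydroxy gives a similar step alongside the 4-chlorophenyl group on the core of compound 1.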